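The source may hold more compounds than are shown below. What is called first, only, known or untested is meant among the compounds shown, and "the series" means these compounds.

Working notes on the series. Compound 1 `COc1ccc(-n2c(-c3cc(OC)c(OC)c(OC)c3)csc2=O)cc1N` in a functional assay on CCRF-CEM cells (Homo sapiens) for antiproliferative activity, with a stated time of 72 h (a lower number here means a stronger inhibitor, a higher number a weaker inhibitor), gives 10100 nM. Compound 2 `COc1ccc(-n2c(-c3cc(OC)c(OC)c(OC)c3)c(Cl)sc2=O)cc1N` in this assay gives 16200 nM; it differs from compound 1 by chloro in place of hydrogen on an aromatic carbon and the step is a 1.6-fold higher number from compound 1 to compound 2 (0.21 log units; within the scatter). Compound 3 `COc1ccc(-c2csc(=O)n2-c2cc(OC)c(OC)c(OC)c2)cc1N` has the same atoms as compound 1, joined differently; the difference between the two cores is not broken down here. In this assay compound 3 gives 240 nM, the lowest of the three numbers, with the gaps to compound 1 and compound 2 both beyond the scatter. Compound 4 `COc1ccc(-c2c(Cl)sc(=O)n2-c2cc(OC)c(OC)c(OC)c2)cc1N` differs from compound 3 by chloro in place of hydrogen on an aromatic carbon. This is the same kind of change as that from compound 1 to compound 2, not the same: here the chloro sits next to the ring atom that bears a 3-amino-4-methoxyphenyl group and two ring bonds from the ring atom that bears a large group, whereas in compound 2 it sits next to the ring atom that bears a large group and two ring bonds from the ring atom that bears a 3-amino-4-methoxyphenyl group. Within the data shown here, a step of a 1.5-fold higher number from compound 3 to compound 4 (0.16 log units; within the scatter) is expected, resting on the one measured example, a 1.6-fold higher number from compound 1 to compound 2 (0.21 log units; within the scatter). Compound 4 is therefore estimated at 350 nM, with a likely range from 150 nM to 900 nM.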

Compound 4, half-maximal inhibitory concentration: 120 nM
For compound 4 the middle estimate is 2.9-fold (0.46 log units) above the measured one, outside the stated range (below it).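

In this assay, chloro in place of hydrogen on an aromatic carbon gives a 2.0-fold lower number from compound 3 to compound 4 (0.30 log units; within the scatter). Carried from one core to the other, the change does not behave as one fixed step: the same change on two cores in this assay, a 1.6-fold higher number (0.21 log units; within the scatter) from compound 1 to compound 2 and a 2.0-fold lower number (0.30 log units; within the scatter) from compound 3 to compound 4, 3.2-fold (0.51 log units) apart, beyond the scatter of two such steps. Each step on its own stays within the scatter, so the result shows that the step on one core is a poor guide to the step on the other, but not that chloro shifts the number on either core, and two pairs support no rule for the series. The compounds shown leave open whether bromo, methyl or nitrile on the same aromatic carbon would give matching steps on the two cores.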